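The compounds below may be only part of what the source reports. "The series", "measured", "known", "first", "only" and "open" are said of these compounds alone.

Measured compounds:
- compound 1 `Cc1ccccc1-c1nnc(SCCn2c([N+](=O)[O-])cnc2C)o1` gives 15800 nM in a functional assay on MCF7 cells (Homo sapiens) for cytotoxicity, read by MTT assay, with a stated time of 48 h; a lower number here means a stronger inhibitor, a higher number a weaker inhibitor
- compound 2 `Cc1ncc([N+](=O)[O-])n1CCSc1nnc(-c2ccccc2F)o1` gives 20500 nM
- compound 3 `Cc1ncc([N+](=O)[O-])n1CCSc1nnc(-c2cccs2)o1` gives 25800 nM

Compound 1 has the lowest of the three numbers, but it is not set apart: its nearest neighbour is compound 2, with a 1.3-fold higher number from compound 1 to compound 2 (0.11 log units; within the scatter), and its furthest is compound 3, with a 1.6-fold higher number from compound 1 to compound 3 (0.21 log units; within the scatter). Among the compounds with values here, both steps sit within the scatter, so no compound can be called more potent than another here.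

Compound 4 `Cc1ncc([N+](=O)[O-])n1CCSc1nnc(-c2ccccn2)o1` is not yet measured. It differs from compound 1 in one place: pyridin-2-yl in place of 2-methylphenyl on an aromatic carbon.

Within the data shown here, two measured steps bear on this change, as both swap the ring that hangs from the same carbon of the shared core. Swapping the ring for a thiophen-2-yl gave a 1.6-fold higher number from compound 1 to compound 3 (0.21 log units; within the scatter), and changing the ring substituent gave a 1.3-fold higher number from compound 1 to compound 2 (0.11 log units; within the scatter); between compounds 2 and 3 the step was a 1.3-fold higher number from compound 2 to compound 3 (0.10 log units; within the scatter). Every swap of this ring so far moved the number by no more than the scatter, so no step beyond the scatter is expected in this assay for compound 4 either.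

The expected step is a 1.3-fold higher number from compound 1 to compound 4 (0.10 log units; within the scatter), and compound 4 is therefore estimated at 20000 nM, with a range from 9000 nM to 45000 nM.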

Compound 4, half-maximal inhibitory concentration: 39100 nM
Compound 4: middle estimate off by 2.0-fold (0.29 log units), on the low side; measured number inside the range.
By their numbers in this assay, from the lowest: compounds 1, 2, 3 and 4 (each within the scatter of the next, the first and the last beyond it).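

In this assay, the swap of pyridin-2-yl for 2-methylphenyl is the only change at this position among the compounds shown that clears the scatter, with a 2.5-fold higher number from compound 1 to compound 4 (0.39 log units; beyond the scatter), a modest step. Against the other two rings the same group stays within the scatter, with a 1.5-fold higher number from compound 3 to compound 4 (0.18 log units; within the scatter) and a 1.9-fold higher number from compound 2 to compound 4 (0.28 log units; within the scatter), so compound 4 is separated only from compound 1, and the ring at this position matters little except across the full span of the four compounds. No measurement here accounts for the step, so the ring nitrogen that enters with pyridin-2-yl cannot be held responsible for it.

The compounds shown leave open whether pyridin-3-yl or pyridin-4-yl would give numbers like that of compound 4, and whether an unsubstituted phenyl or a ring carrying an amine or a carboxylic acid would move the number any further. As far as these compounds go, all four compounds also keep the rest of the shared core, so the effect of a longer chain in that part remains unknown.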